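This account rests on a few compounds, and the source may have more. Where it says the series, first, only, none or still open, it means among the compounds named here.

Compound 1 `O=C(Nc1ccccn1)c1cc2n(n1)CCCC2` in a functional assay on HEK293 cells for negative allosteric modulation of metabotropic glutamate receptor 5 (Rattus norvegicus), read by FLIPR and calcium flux, with a stated time of 170 s (a higher number here means a weaker inhibitor, a lower number a stronger inhibitor), gives 364 nM. Compound 2 `N#Cc1ccc(NC(=O)c2cc3n(n2)CCCC3)nc1` gives 90 nM, and compound 3 `O=C(Nc1ccc(F)cn1)c1cc2n(n1)CCCC2` gives 60 nM, the lowest of the three numbers, though the nearest step is a 1.5-fold lower number from compound 2 to compound 3 (0.18 log units; within the scatter) and lies within the scatter. Against the unsubstituted parent the steps are a 4.0-fold lower number from compound 1 to compound 2 (0.61 log units; beyond the scatter) and a 6.1-fold lower number from compound 1 to compound 3 (0.78 log units; beyond the scatter). Compound 4 `O=C(Nc1ccc(Cl)cn1)c1cc2n(n1)CCCC2` differs from compound 3 by chloro in place of fluoro on an aromatic carbon. For the measured compounds named here, the steps that bear on this are those at the same aromatic carbon: replacing hydrogen by cyano or by fluoro each gave a modest lower number, while exchanging cyano for fluoro stayed within the scatter, so the presence of a substituent here has mattered more than its identity. For compound 4 no step beyond the scatter is therefore expected, a 1.2-fold lower number from compound 3 to compound 4 (0.08 log units; within the scatter). Compound 4 is estimated at 50 nM, in the range 20 nM to 150 nM.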

Compound 4, half-maximal inhibitory concentration: 262 nM
Estimate against measurement, compound 4: 5.2-fold (0.72 log units) below; the measured number lies above the stated range.
By their numbers in this assay, from the lowest: compounds 3 and 2 (each within the scatter of the next); then compounds 4 and 1 (each within the scatter of the next).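

At this place on the ring, two atoms from the ring nitrogen, the identity of the substituent counts and not only its presence: chloro in place of fluoro gives a 4.4-fold higher number from compound 3 to compound 4 (0.64 log units; beyond the scatter), and chloro in place of cyano gives a 2.9-fold higher number from compound 2 to compound 4 (0.46 log units; beyond the scatter). Chloro in place of hydrogen gives a 1.4-fold lower number from compound 1 to compound 4 (0.14 log units; within the scatter), so chloro stays within the scatter of the parent, while the fluoro of compound 3 and the cyano of compound 2 both go against any rule that substitution alone lowers the number. No measurement at hand accounts for the gap between chloro and fluoro.

From the compounds shown here alone, whether a methyl, methoxy or bromo group here would track with fluoro or with chloro remains open. So does the effect of an amine or a carboxylic acid at this place.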